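A few compounds are considered here, and "the series" means these few. Any claim that something is new, unique, unknown or untested is made for them only; others in the source may bear on it.

Measured compounds:
compound 1 `O=c1cc(-c2ccccc2)oc2cc(OCCCN3CCN(c4ccccc4)CC3)ccc12` gives 6.65 nM
compound 2 `O=c1cc(-c2ccccc2)oc2cc(OCCCCN3CCN(c4ccccc4)CC3)ccc12` gives 4.65 nM

In a functional assay for antagonist activity at Adrenergic receptor alpha-1 (Rattus norvegicus) (a lower number here means tighter binding, a higher number weaker binding), compound 1 and compound 2 lie within the scatter of each other, so the two numbers cannot be told apart; the pair differs only in the length of the chain that joins the core to the piperazine.

Compound 3 `Cc1ccc(N2CCN(CCCOc3ccc4c(=O)cc(-c5ccccc5)oc4c3)CC2)cc1` has not yet been measured. It differs from compound 1 by methyl in place of hydrogen on an aromatic carbon. For the measured compounds named here, no pair among the measured compounds shows what such a change does here, so the expectation rests on the two measured values alone. The author expects the step of a 1.1-fold lower number from compound 1 to compound 3 (0.04 log units; within the scatter) to stay within the scatter, with no clear direction. For compound 3 the estimated value in this assay is 6 nM, with a range from 2.5 nM to 15 nM.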

Compound 3, dissociation constant: 20.7 nM
For compound 3 the middle estimate is 3.5-fold (0.54 log units) below the measured one; measured number outside the range, above it.
By their numbers in this assay, from the lowest: compounds 2 and 1 (each within the scatter of the next); then compound 3.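

In this assay the change from phenyl to 4-methylphenyl gives a 3.1-fold higher number from compound 1 to compound 3 (0.49 log units; beyond the scatter) and so moves the number towards weaker binding, a modest step but one beyond the scatter. This shows that the position on the aromatic ring, para to a large group, is not indifferent to substitution: a single added methyl, with one heavy atom and no hydrogen-bond donors or acceptors, is enough to shift the value. Nothing available here explains why the number rises.

On these data alone, whether a methoxy group or a chlorine atom at this position would shift the number in the same way remains open, as does the effect of a methyl elsewhere on that ring. As far as these compounds go, it is also open whether the same change on the longer chain of compound 2 would give a step of similar size.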